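A propyl group added to compound 2

A few compounds are considered here, and "the series" means these few. Any claim that something is new, unique, unknown or untested is made for them only; others in the source may bear on it.

Compound 1 `O=C(O)c1cc(=O)c2ccc(OCC(O)COc3ccccc3)cc2o1`: 7 ug/mL
Compound 2 `CC(=O)c1ccc(OCC(O)COc2ccc3c(=O)cc(C(=O)O)oc3c2)cc1O`: 28 ug/mL
Compound 3 `C=CCc1c(OCC(O)COc2ccc(C(C)=O)c(O)c2)ccc2c(=O)cc(C(=O)O)oc12`: 3.3 ug/mL

In a functional assay on ileum (Cavia porcellus) for antagonist activity, with a stated time of 30 s (on this read-out higher numbers stand for weaker inhibition and lower numbers for stronger inhibition), compound 2 has the highest of the three numbers at 28 ug/mL, which makes it the weakest inhibitor of the set. The numbers for the other two are lower, with compound 1 at 7 ug/mL and compound 3 at 3.3 ug/mL.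

Compound 4 `CCCc1c(OCC(O)COc2ccc3c(=O)cc(C(=O)O)oc3c2)ccc(C(C)=O)c1O` has not yet been measured. It differs from compound 2 by propyl in place of hydrogen on an aromatic carbon, with propyl in place of hydrogen on an aromatic carbon, ortho to a hydroxy group and meta to an acetyl group.

Among the compounds with values here, two measured steps bear on this change. The closer one is an 8.5-fold lower number from compound 2 to compound 3 (0.93 log units; beyond the scatter), with allyl in place of hydrogen on an aromatic carbon. That allyl does not stand where the propyl of compound 4 stands, and allyl is not propyl, so this step is only a rough guide. The other is a 4.0-fold higher number from compound 1 to compound 2 (0.60 log units; beyond the scatter), with 4-acetyl-3-hydroxyphenyl in place of phenyl, and it shows that this group can shift the number. Within the data shown here, no measured step places a chain at the site of the propyl.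

The expected step is a 2.8-fold lower number from compound 2 to compound 4 (0.45 log units; beyond the scatter), in the same direction as the allyl step but smaller. For compound 4 the estimated value is 10 ug/mL, with an expected range from 3 ug/mL to 30 ug/mL.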

Compound 4, half-maximal inhibitory concentration: 0.08 ug/mL
Compound 4: middle estimate off by 130-fold (2.10 log units), on the high side; measured number below the stated range.
By their numbers in this assay, from the lowest: compound 4; then compound 3; then compound 1; then compound 2.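

In this assay, the propyl group on the aromatic carbon ortho to a hydroxy group and meta to an acetyl group produces a far larger change than any earlier step (a 350-fold lower number from compound 2 to compound 4 (2.54 log units; beyond the scatter)). The earlier allyl step, at a different aromatic carbon, was much smaller (an 8.5-fold lower number from compound 2 to compound 3 (0.93 log units; beyond the scatter)), so it did not reveal how sensitive the read-out is to a chain at this site. No measurement available here accounts for the size of this step, so the reason for it remains unknown.

The compounds shown leave open how the effect depends on chain length and type at this site, for instance whether a methyl group, a butyl chain or an allyl group would give a step of similar size, or whether an amine would retain any of it. They also leave open whether the step depends on the neighbouring hydroxy and acetyl groups, since propyl appears here only in the company of both.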